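The source may hold more compounds than are shown below. What is called first, only, known or untested is meant among the compounds shown, and "the series" means these compounds.

Compounds measured in a functional assay on the whole organism (Tail, strain ICR) with Mus musculus as the target, in the tail flick test, with a stated time of 30 min, at a dose of 25 umol/kg by the oral route; a higher number here means a stronger effect of the compound at the dose given, a lower number a weaker effect:
compound 1 `CSCC[C@H](NC(=O)CN(c1nc(Cl)nc2[nH]cnc12)C1CC1)C(=O)OCc1ccccc1` gives 22.2%;
compound 2 `NCCCC[C@H](NC(=O)CN(c1nc(Cl)nc2[nH]cnc12)C1CC1)C(=O)OCc1ccccc1` gives 26.1%;
compound 3 `CC(C)[C@H](NC(=O)CN(c1nc(Cl)nc2[nH]cnc12)C1CC1)C(=O)OCc1ccccc1` gives 33.4%.

Among these three, compound 1 stands lowest: the gap a number 3.9 percentage points higher from compound 1 to compound 2 (within the scatter) lies within the scatter, while a number 11.2 percentage points higher from compound 1 to compound 3 (beyond the scatter) is beyond it, and a number 7.3 percentage points higher from compound 2 to compound 3 (within the scatter) again within. All three measured steps alter the side chain on the saturated chain carbon; none of them touches the ester.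

Compound 4 `CSCC[C@H](NC(=O)CN(c1nc(Cl)nc2[nH]cnc12)C1CC1)C(=O)O` differs from compound 1 as follows: hydrogen in place of benzyl on an oxygen next to a carbonyl group. Among the measured compounds shown here, no measured step bears on a change at this place, so nothing in the data predicts its direction or size. Compound 4 is therefore expected to stay close to compound 1, the step of a number 4.2 percentage points lower from compound 1 to compound 4 (within the scatter) being an estimate with wide uncertainty. Compound 4 is estimated at 18%, within 4% to 34%.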

Compound 4, a percentage reported as activity, at one dose (the size of the read-out at that dose, not a potency): 20.4%
For compound 4 the middle estimate is 2.4 percentage points below the measured one; measured number inside the range.
By their numbers in this assay, from the lowest: compounds 4, 1, 2 and 3 (each within the scatter of the next, the first and the last beyond it).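

In this assay, hydrogen in place of benzyl on an oxygen next to a carbonyl group gives a number 1.8 percentage points lower from compound 1 to compound 4 (within the scatter). With the 2-(methylsulfanyl)ethyl side chain, the ester position therefore tolerates loss of the benzyl group without a difference that can be read beyond the scatter. No measurement at hand offers an explanation for this result.

From the compounds shown here alone, whether the same holds for the free acids of the isopropyl and 4-aminobutyl side chains remains open. So does the effect of a methyl ester or a primary amide at this place.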